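The compounds below may be only part of what the source reports. "The series", "measured", "known", "first", "only" and "open" are said of these compounds alone.

For the measured compounds named here, compound 3, with the structure `CCOc1c(-c2occ(C)c2C(=O)OC)ccc2c(CC)cccc12`, stands second highest of the three numbers so far in a functional assay on SK-BR-3 cells (Homo sapiens) for cytotoxicity, read by MTT assay, with a stated time of 72 h (on this read-out higher numbers stand for an effect only at larger amounts of compound and lower numbers for an effect already at smaller amounts), where compound 3 gives 1.9 ug/mL. Its nearest neighbour is compound 1, structure `CCc1cccc2c(OC)c(-c3occ(C)c3C(=O)OC)ccc12`, which in this assay gives 1.2 ug/mL; the step of a 1.6-fold higher number from compound 1 to compound 3 (0.20 log units; within the scatter) lies within the scatter. Furthest away is compound 2, structure `CCc1cccc2c(OC)c(-c3occ(C)c3C(=S)OC)ccc12`, which gives 6.3 ug/mL, reached from compound 1 by the step of a 5.3-fold higher number from compound 1 to compound 2 (0.72 log units; beyond the scatter).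

Compound 4, structure `CCOc1c(-c2occ(C)c2COC(C)=O)ccc2c(CC)cccc12`, differs from compound 3 by the change (acetoxymethyl in place of methoxycarbonyl on an aromatic carbon). Going by the values given here, of the measured steps, only the one from compound 1 to compound 2 touches the same group on the five-membered ring, and there an alteration of the methoxycarbonyl group raised the number modestly. Among the compounds with values here, since the change to acetoxymethyl is a larger rearrangement of that group than the one seen between compound 1 and compound 2, a step of similar or somewhat larger size towards a higher number is expected, a 2.4-fold higher number from compound 3 to compound 4 (0.37 log units; beyond the scatter). Compound 4 is therefore estimated to give 4.5 ug/mL in this assay, within a range from 1.5 ug/mL to 15 ug/mL.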

Compound 4, concentration for half-maximal effect: > 10 ug/mL
Compound 4 gave a limit, no number (the forecaster's own chance of this, stated with the estimate: 5%); middle value at least 2.2-fold (0.34 log units) away from the limit.
By their numbers in this assay, from the lowest: compounds 1 and 3 (each within the scatter of the next); then compound 2. At a limit, above all of these: compound 4.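

In this assay, compound 4 gave only a limit, > 10 ug/mL, not a number. Putting acetoxymethyl in place of methoxycarbonyl on this aromatic carbon of the five-membered ring gives an at least 5.2-fold higher number from compound 3 to compound 4 (0.72 log units; beyond the scatter), so the number moves beyond the scatter even though the counts of hydrogen-bond donors and acceptors stay the same. The full size of this step cannot be read, and only its lower bound is known: the limit of > 10 ug/mL in this assay, at which 1 of the 4 values shown sits.

The compounds shown leave open how a carboxylic acid, an amide or a hydroxymethyl group would read on this carbon. They also leave open whether acetoxymethyl would give a similar step on the core of compound 1.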